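Bridged bicyclic amines at the neuronal nicotinic receptor

The source may report more compounds than this note shows. Statements on the series, on what has been measured and on what is new or still open speak of the compounds shown alone.

Compound 1 `COc1ccccc1C1=NCC2(CN3CCC2CC3)NC(=O)C1`: "not determined" (no result reported)
Compound 2 `O=C1CC(c2ccco2)=NCC2(CN3CCC2CC3)N1`: "not determined" (no result reported)
Compound 3 `Oc1c(C2=NC3(CN2)CN2CCC3CC2)oc2ccccc12`: 55%

Three compounds of the series have entries in an assay on cell membranes from SH-SY5Y cells for displacement of a labelled ligand from Neuronal acetylcholine receptor; alpha3/beta4 (Homo sapiens), read by scintillation counting, with a stated time of 2 h, tested at 5 uM; a lower number here means less inhibition, a higher number more inhibition at the concentration tested (going by the name of the read-out). For compound 1 the entry is "not determined" (no result reported), and for compound 2 it is "not determined" (no result reported); neither contributes a number. Going by the values given here, compound 3 is therefore the only member with a figure: in this assay compound 3 gives 55%, a moderate degree of displacement at the single concentration tested.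

Compound 4 `c1ccc2oc(C3=NC4(CN3)CN3CCC4CC3)cc2c1` is the next entry awaiting its result. It differs from compound 3 by hydrogen in place of hydroxy on an aromatic carbon. Among the compounds with values here, no pair of measured compounds differing in one place is available, so there is no measured step to lean on, and the hydroxy group is not varied anywhere else. Within the data shown here, the expectation for compound 4 is a step of a number 10 percentage points lower from compound 3 to compound 4 (within the scatter) that stays within the usual scatter, leaning if anything downward, since the only anchor is compound 3 at 55%. Compound 4 is estimated at 45%, with a range from 20% to 70%.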

Compound 4, a percentage reported as inhibition, at one concentration (the size of the read-out at that concentration, not a potency): 13%
The estimate for compound 4 lay 32 percentage points above the measured number; measured number outside the range, below it.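

In this assay, going by these compounds alone, the change to hydrogen in place of hydroxy gives a number 42 percentage points lower from compound 3 to compound 4 (beyond the scatter) and is the first measured step. It shows that the figure at the concentration tested is sensitive to what stands on this aromatic carbon of the five-membered aromatic ring, next to the ring atom that bears a large group, with hydroxy giving the higher number of the pair. Nothing available accounts for the size of this step.

The compounds shown leave open how a methoxy group, an amine or a fluorine on the same carbon would compare with hydroxy and hydrogen. Also open, as far as these compounds go, is whether this change would produce a step of similar size on a core other than that of compound 3.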